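The source may report more compounds than this note shows. Statements on the series, on what has been measured and on what is new or still open speak of the compounds shown alone.

Compound 1 `CN1CCN(CCNCc2cn(-c3ccc(F)cc3F)nc2Cc2ccccc2)CC1` — > 20000 nM
Compound 2 `CN1CCN(CCNCc2cn(-c3ccc(F)cc3F)nc2-c2ccc(OC(F)(F)F)cc2)CC1` — 18000 nM

In an ADME assay on Huh-7 cells (Homo sapiens) for cytotoxicity (a lower number here means that less compound is tolerated, a higher number that more compound is tolerated), compound 2 gives 18000 nM. Compound 1 is reported only as > 20000 nM, which is a limit of the assay rather than a number. Among the values shown, compound 2 therefore holds the only number; the other value is a limit, as the limit of > 20000 nM in this assay, at which 1 of the 2 values shown sits, records. Among the compounds with values here, the single measured step, an at least 1.1-fold lower number from compound 1 to compound 2 (0.04 log units; that floor lies within the scatter), swaps the group on an aromatic carbon and stays within the scatter of repeated measurements.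

Compound 3 `CN1CCN(CCNCc2cn(-c3ccc(C(F)(F)F)cc3)nc2-c2ccc(OC(F)(F)F)cc2)CC1` differs from compound 2 at another place: 4-(trifluoromethyl)phenyl in place of 2,4-difluorophenyl on an aromatic nitrogen. The measured step does not touch this group, so it bears on the new change only by showing that a group swap elsewhere in the shared core left this assay unmoved. With nothing pointing in either direction, no step beyond the scatter is expected in this assay from compound 2 to compound 3; the expected step is no change at the digits printed from compound 2 to compound 3 (within the scatter). Compound 3 is thus estimated at 18000 nM, within a range from 8000 nM to 40000 nM, with a fair chance that only a limit is reported.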

Compound 3, half-maximal cytotoxic concentration: 3000 nM
Compound 3: the middle estimate sits 6.0-fold (0.78 log units) above what was measured; measured number below the stated range.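

In this assay, within the data shown here, the aromatic nitrogen proves to be a place where the choice of group counts: 4-(trifluoromethyl)phenyl in place of 2,4-difluorophenyl gives a 6.0-fold lower number from compound 2 to compound 3 (0.78 log units; beyond the scatter) and marks the first step in these compounds that clearly exceeds the usual scatter. Less of compound 3 than of compound 2 is tolerated by the cells, whereas the earlier swap on the aromatic carbon gave no step that could be told apart from the scatter. The swap at the nitrogen is also a modest one on paper, since both groups have one six-membered aromatic ring of carbon only, no hydrogen-bond donors or acceptors and no net charge, with 10 heavy atoms entering and 8 leaving.

Nothing shown here speaks to what lies behind this step. Compound 3 both loses the two ring fluorines and gains the trifluoromethyl group, so a plain phenyl, or a phenyl carrying a single fluorine or a nitrile, on the aromatic nitrogen could show which of the two changes goes with the lower number.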